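Adding a Trifluoromethyl Group to Compound 1

The source may report more compounds than this note shows. Statements on the series, on what has been measured and on what is new or still open speak of the compounds shown alone.

Measured compounds in an ADME assay on NIH3T3 cells (Mus musculus) for cytotoxicity, read by XTT assay, with a stated time of 24 h; on this read-out higher numbers stand for weaker inhibition and lower numbers for stronger inhibition:
- compound 1, `Fc1ccc(C2CC(c3ccc(Cl)s3)=NN2c2nc(-c3ccccc3)cs2)cc1`: compound 1 gives > 500 ug/mL
- compound 2, `Cc1ccc(C2=NN(c3nc(-c4ccc(C#N)cc4)cs3)C(c3ccc(F)cc3)C2)s1`: compound 2 gives 250 ug/mL
- compound 3, `Cc1ccc(C2=NN(c3nc(-c4ccc([N+](=O)[O-])cc4)cs3)C(c3ccc(F)cc3)C2)s1`: compound 3 gives 15.6 ug/mL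

The value of compound 1 is a limit of the assay, not a number (the limit of > 500 ug/mL in this assay, at which 1 of the 3 values shown sits), so compound 1 stands at the weak end of what was seen. Compound 4, `Fc1ccc(C2CC(c3ccc(Cl)s3)=NN2c2nc(-c3ccc(C(F)(F)F)cc3)cs2)cc1`, differs from compound 1 by one change: trifluoromethyl in place of hydrogen on an aromatic carbon.

Going by the values given here, only one measured step is known, a 16-fold lower number from compound 2 to compound 3 (1.20 log units; beyond the scatter). Among the compounds with values here, it concerns a different exchange on the same phenyl ring, so it does not match the change from compound 1 to compound 4; it shows only that a change at this place can move the number far. For compound 4 a step of no more than the scatter is expected, an at least 1.2-fold lower number from compound 1 to compound 4 (0.09 log units; that floor lies within the scatter), and the value is expected to stay high. The estimate for compound 4 is 400 ug/mL, between 120 ug/mL and 500 ug/mL, with a fair chance that only a limit is reported again.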

Compound 4, half-maximal inhibitory concentration: > 500 ug/mL
Compound 4 was reported as a limit; the forecaster's own chance of this, stated with the estimate: 55%; middle value at least 1.2-fold (0.09 log units) from the limit.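

In this assay compound 1 and compound 4 both stand at a limit rather than a number, so no step between them can be read: the limit of > 500 ug/mL in this assay, at which 2 of the 4 values shown sit.

The compounds shown leave open whether trifluoromethyl in place of hydrogen on this phenyl ring changes the number at all.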